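Methyl for chloro with hydroxy on the carbonyl carbon

The source may report more compounds than this note shows. Statements on the series, on what has been measured and on what is new or still open speak of the compounds shown alone.

In a physicochemical assay for lipophilicity, read by HPLC, at pH 7.5 (on this read-out higher numbers stand for higher lipophilicity and lower numbers for lower lipophilicity), compound 1 `CC[C@@H](Nc1c(C#N)c(-c2ccc(-c3cccc(C)c3F)cc2)nc2cnccc12)C(N)=O` gives 3 and compound 2 `CC[C@@H](Nc1c(C#N)c(-c2ccc(-c3cccc(Cl)c3F)cc2)nc2cnccc12)C(N)=O` gives 3.1. Compound 3 `CC[C@@H](Nc1c(C#N)c(-c2ccc(-c3cccc(Cl)c3F)cc2)nc2cnccc12)C(=O)O` gives 2.2, the lowest of the three numbers. The open question is compound 4 `CC[C@@H](Nc1c(C#N)c(-c2ccc(-c3cccc(C)c3F)cc2)nc2cnccc12)C(=O)O`, which differs from compound 3 by methyl in place of chloro on an aromatic carbon.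

Within the data shown here, two measured steps bear on this change. The closest is the same exchange in the opposite direction, with amino on the carbonyl carbon, which gave a number 0.10 log units higher from compound 1 to compound 2 (within the scatter). The other, hydroxy in place of amino on a carbonyl carbon, gave a number 0.90 log units lower from compound 2 to compound 3 (beyond the scatter). That step is modest and lies at a different place in the molecule. If it carries over to the methyl side, compound 1 at 3 would come down by a similar amount. Among the measured compounds shown here, only one measured pair covers the exchange itself, and no such pair yet exists with hydroxy on the carbonyl carbon.

With only the small step of a number 0.10 log units higher from compound 1 to compound 2 (within the scatter) as a guide, no change beyond the scatter is expected in this assay. The expected step is a number 0.10 log units lower from compound 3 to compound 4 (within the scatter). The estimate for compound 4 is 2.1, with an expected range from 1.8 to 2.4.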

Compound 4, distribution coefficient: 2.1
Compound 4: middle estimate and measured number agree at the digits printed, within the range that was stated.
By their numbers in this assay, from the lowest: compounds 4 and 3 (each within the scatter of the next); then compounds 1 and 2 (each within the scatter of the next).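

In this assay, the exchange of chloro and methyl on the aromatic carbon ortho to a fluoro group now has a pair with hydroxy on the carbonyl carbon, a number 0.10 log units lower from compound 3 to compound 4 (within the scatter), so the two groups are not told apart with either amino or hydroxy there. Among these compounds, the exchange of amino for hydroxy on the carbonyl carbon, earlier seen only with chloro on the aromatic ring, now also has a pair with methyl there, a number 0.90 log units lower from compound 1 to compound 4 (beyond the scatter), the same size as a number 0.90 log units lower from compound 2 to compound 3 (beyond the scatter). Across these four compounds the two exchanges therefore read as independent: the number moves with the group on the carbonyl carbon and not with the group on the aromatic carbon. No measurement at hand gives a reason for either step.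

As far as these compounds go, whether this position stays as flat for groups other than chloro and methyl remains open, for example with hydrogen, methoxy or trifluoromethyl there. Also open, from the compounds shown here alone, is whether the step on the carbonyl carbon keeps its size with a group other than amino or hydroxy, such as methylamino or methoxy.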